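The source may hold more compounds than are shown below. What is called first, only, known or untested is meant among the compounds shown, and "the series" means these compounds.

Measured so far:
compound 1 `O=C(Nc1cccc(-n2cc(-c3ccncc3)c(-c3cc(O)cc(Cl)c3)n2)c1)Nc1ccc(Cl)c(C(F)(F)F)c1`: 102%
compound 2 `O=C(Nc1cccc(-n2cc(-c3ccncc3)c(-c3cc(O)cc(Cl)c3)n2)c1)Nc1ccc(Cl)c(Cl)c1`: 102%
compound 3 `COc1cc(Cl)cc(-c2nn(-c3cccc(NC(=O)Nc4ccc(Cl)c(C(F)(F)F)c4)c3)cc2-c2ccncc2)c1`: 98%

In a functional assay on OVCAR-8 cells (Homo sapiens) for inhibition, read by sulforhodamine B assay, with a stated time of 48 h, tested at 0.01 uM (on this read-out higher numbers stand for a weaker effect at the one concentration tested and lower numbers for a stronger effect), compound 1 gives 102%, compound 2 gives 102% and compound 3 gives 98%. Compound 3 carries the lowest of the three numbers, but its gap to compound 1 and to compound 2 lies within the scatter, so no order among the three can be read.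

Compound 4 `COc1cc(Cl)cc(-c2nn(-c3cccc(NC(=O)Nc4ccc(Cl)c(Cl)c4)c3)cc2-c2ccncc2)c1` differs from compound 3 by chloro in place of trifluoromethyl on an aromatic carbon. The same change has been measured once, between compound 1 and compound 2: no change at the digits printed from compound 1 to compound 2 (within the scatter). Compound 3 itself sits where a number 4 percentage points lower from compound 1 to compound 3 (within the scatter) places it. On this basis the expected step in this assay is a number 1 percentage points higher from compound 3 to compound 4 (within the scatter), nothing beyond the scatter, and compound 4 is estimated at 99%, in the range 90% to 108%.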

Compound 4, a percentage reported as activity, at one concentration (the size of the read-out at that concentration, not a potency): 96%
Estimate against measurement, compound 4: 3 percentage points above; the range from low to high includes it.
By their numbers in this assay, from the lowest: compounds 4, 3, 1 and 2 (each within the scatter of the next).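

In this assay chloro in place of trifluoromethyl on this aromatic carbon gives a number 2 percentage points lower from compound 3 to compound 4 (within the scatter) and so reads alike on a second core: the same change on two cores in this assay, no change at the digits printed (within the scatter) from compound 1 to compound 2 and a number 2 percentage points lower (within the scatter) from compound 3 to compound 4, 2 percentage points apart, within the scatter of two such steps. Methyl in place of hydrogen on the oxygen gives a number 6 percentage points lower from compound 2 to compound 4 (within the scatter) and also reads alike with either group at this position: the same change on two cores in this assay, a number 4 percentage points lower (within the scatter) from compound 1 to compound 3 and a number 6 percentage points lower (within the scatter) from compound 2 to compound 4, 2 percentage points apart, within the scatter of two such steps. Neither change moves the read-out beyond the scatter on either core at this one concentration.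

As far as these compounds go, whether an amine or a carboxylic acid at this position would shift the number remains open, as does a longer chain on the oxygen.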